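Swapping propargyl for cyclopropyl on the amide nitrogen

This account rests on a few compounds, and the source may have more. Where it says the series, first, only, none or still open, it means among the compounds named here.

This account concerns two compounds measured in a toxicity assay on the whole organism (strain Icem-CET (SPF Caw)) for cytotoxicity, with Mus musculus as the target (a higher number here means that more compound is needed for the effect, a lower number that less compound is needed), and a third awaiting measurement. Compound 1 `C/C(C(=O)NC1CC1)=C(/C)c1ccc(Br)cc1` gives 130 mg/kg in this assay. Compound 2 `C#CCNC(=O)/C(C)=C(\C)c1ccccc1` gives 150 mg/kg in this assay, the higher of the two numbers, though its gap to compound 1 lies within the usual scatter, so the two values cannot be ordered with confidence. Compound 3 `C/C(C(=O)NC1CC1)=C(/C)c1ccccc1` differs from compound 2 in one place: cyclopropyl in place of propargyl on an amide-type nitrogen. Going by the values given here, no step between measured compounds isolates this change, so the expectation rests on the narrow spread seen so far. With compound 1 at 130 mg/kg and compound 2 at 150 mg/kg both sitting close together, the step from compound 2 to compound 3 in this assay is expected to be small, in no particular direction, as a 1.1-fold lower number from compound 2 to compound 3 (0.03 log units; within the scatter). Compound 3 is therefore estimated to give 140 mg/kg in this assay, within a range from 70 mg/kg to 280 mg/kg.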

Compound 3, dose for half-maximal effect: 150 mg/kg
Estimate against measurement, compound 3: 1.1-fold (0.03 log units) below; the range from low to high includes it.
By their numbers in this assay, from the lowest: compounds 1, 2 and 3 (each within the scatter of the next).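

In this assay, cyclopropyl in place of propargyl on an amide-type nitrogen gives no change at the digits printed from compound 2 to compound 3 (within the scatter), so this position now has a direct reading: exchanging an open chain with a triple bond for a three-membered ring of the same heavy-atom count leaves the number within the scatter. Compound 3 also provides a direct reading of a second change, as hydrogen in place of bromo on an aromatic carbon gives a 1.2-fold higher number from compound 1 to compound 3 (0.06 log units; within the scatter), again within the scatter. No measurement shown here bears on why either change leaves the number within the scatter.

The compounds shown leave open whether a longer chain, an amine or a carboxylic acid on the amide-type nitrogen would move the number beyond the scatter. On these data alone, it is equally open whether methoxy or chloro in place of bromo on the aromatic carbon would do so.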